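Thioether aryl swap on a quinazoline ester side chain

The compounds below may be only part of what the source reports. "The series", "measured", "known", "first", "only" and "open" are said of these compounds alone.

Compound 1, `CCOc1cc2ncnc(Nc3ccc(F)c(Cl)c3)c2cc1OC(=O)CSc1ccccn1`: in a functional assay on NCI-H1975 cells (Homo sapiens) for inhibition, read by MTT assay, with a stated time of 72 h (a lower number here means a stronger inhibitor, a higher number a weaker inhibitor), compound 1 gives 3700 nM.
Compound 2, `CCOc1cc2ncnc(Nc3ccc(F)c(Cl)c3)c2cc1OC(=O)CSc1ncc[nH]1`: in this assay compound 2 gives 1400 nM.

Compound 2 stands with the lowest of the two numbers, its nearest neighbour being compound 1. Compound 3, `CCOc1cc2ncnc(Nc3ccc(F)c(Cl)c3)c2cc1OC(=O)CSc1nc2cc(OC)ccc2s1`, carries 5-methoxy-1,3-benzothiazol-2-yl in place of 1H-imidazol-2-yl on a sulfur. Among the compounds with values here, the single measured step, a 2.6-fold lower number from compound 1 to compound 2 (0.42 log units; beyond the scatter), exchanged one small ring for another and does not cover the entry of a fused bicyclic group, so it bears only loosely on this change. Compound 3 is therefore expected to give about 3000 nM, within 800 nM to 10000 nM. This estimate corresponds to a step of a 2.1-fold higher number from compound 2 to compound 3 (0.33 log units; beyond the scatter), with wide uncertainty.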

Compound 3, half-maximal inhibitory concentration: 3200 nM
Compound 3: the middle estimate sits 1.1-fold (0.03 log units) below what was measured; the measured number falls inside the stated range.
By their numbers in this assay, from the lowest: compound 2; then compounds 3 and 1 (each within the scatter of the next).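

In this assay, placing the fused 5-methoxy-1,3-benzothiazol-2-yl group on the sulfur gives a 2.3-fold higher number from compound 2 to compound 3 (0.36 log units; beyond the scatter) and does not keep the lower number seen with 1H-imidazol-2-yl. Compared with pyridin-2-yl, the same group gives a 1.2-fold lower number from compound 1 to compound 3 (0.06 log units; within the scatter) and thus shows that this position accepts a group of 11 heavy atoms with the number staying within the scatter. No available evidence accounts for these differences. The compounds shown leave open what an unsubstituted 1,3-benzothiazol-2-yl group or a 1-methylimidazol-2-yl group would give, and so whether the methoxy or the fused ring accounts for the step from the imidazole.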